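The source may report more compounds than this note shows. Statements on the series, on what has been measured and on what is new or still open speak of the compounds shown alone.

Within the data shown here, in a functional assay on PC-3 cells (Homo sapiens) for antiproliferative activity, read by MTT assay, with a stated time of 48 h (a higher number here means a weaker inhibitor, a lower number a stronger inhibitor), compound 1 `COc1ccccc1/C=C1\SC(N[C@H](C(=O)NS(=O)(=O)c2ccc(C)cc2)C(C)C)=NC1=O` gives 15 ug/mL and compound 2 `COc1ccc(/C=C2\SC(N[C@H](C(=O)NS(=O)(=O)c3ccc(C)cc3)C(C)C)=NC2=O)cc1` gives 20.3 ug/mL, so compound 2 stands within the scatter of the only other measured compound. Compound 3 `Cc1ccc(S(=O)(=O)NC(=O)[C@@H](NC2=NC(=O)/C(=C/c3ccccc3)S2)C(C)C)cc1` differs from compound 2 by hydrogen in place of methoxy on an aromatic carbon. Among the measured compounds shown here, the one measured step, a 1.4-fold higher number from compound 1 to compound 2 (0.13 log units; within the scatter), relocates that methoxy group but does not remove it, so it bears only indirectly. No change beyond the scatter is therefore expected in this assay. The expected step is a 1.1-fold lower number from compound 2 to compound 3 (0.05 log units; within the scatter). Compound 3 is estimated at 18 ug/mL, with an expected range of 9 ug/mL to 35 ug/mL.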

Compound 3, half-maximal inhibitory concentration: 11.9 ug/mL
For compound 3 the middle estimate is 1.5-fold (0.18 log units) above the measured one; the range from low to high includes it.
By their numbers in this assay, from the lowest: compounds 3, 1 and 2 (each within the scatter of the next).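

In this assay the methoxy group is now taken off the aromatic ring rather than moved: 4-methoxyphenyl to phenyl gives a 1.7-fold lower number from compound 2 to compound 3 (0.23 log units; within the scatter) and the same removal from the other methoxy placement gives a 1.3-fold lower number from compound 1 to compound 3 (0.10 log units; within the scatter) in this series. Neither methoxy placement stands apart from the plain phenyl, so the methoxy group is not needed to keep the number in this range. No measured evidence bears on these small steps. On these data alone, whether an amine or a carboxylic acid on this ring would carry the number beyond the scatter stays open.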